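Bromo in place of methoxy: growth inhibition notes

This account rests on a few compounds, and the source may have more. Where it says the series, first, only, none or still open, it means among the compounds named here.

Of the compounds shown here, two with the same core have been measured, compound 1 `CN(C)C(=O)c1cc2cnc(Nc3ccc(NC(=O)C4(C(=O)Nc5cccc(O)c5)CC4)cc3)nc2n1C1CCCC1` and compound 2 `COc1cccc(NC(=O)C2(C(=O)Nc3ccc(Nc4ncc5cc(C(=O)N(C)C)n(C6CCCC6)c5n4)cc3)CC2)c1`. In a functional assay on T47D cells (Homo sapiens) for inhibition, read by CCK-8 assay, with a stated time of 72 h, tested at 1 uM (on this read-out lower numbers stand for less inhibition of growth and higher numbers for more inhibition of growth at the one concentration tested), compound 1 gives 80.7% and compound 2 gives 56.3%, the lower of the two numbers. For the measured compounds named here, the only measured step is a number 24.4 percentage points lower from compound 1 to compound 2 (beyond the scatter), and it comes from methyl in place of hydrogen on an oxygen on an aromatic ring.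

The next compound is compound 3 `CN(C)C(=O)c1cc2cnc(Nc3ccc(NC(=O)C4(C(=O)Nc5cccc(Br)c5)CC4)cc3)nc2n1C1CCCC1`, with bromo in place of methoxy on an aromatic carbon, meta to a large group: bromo in place of methoxy on an aromatic carbon. The measured step involves the same substituent as this change. Going by the values given here, no measured compound carries bromo. That single step therefore gives the sensitivity of this assay to a change here, not the size of this one. Compound 1 at 80.7% shows that values well above compound 2 are reachable, so a small upward move is expected.

The estimated step is a number 8.7 percentage points higher from compound 2 to compound 3 (within the scatter).

For compound 3 the expected value is 65%, with an estimated range from 45% to 84%.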

Compound 3, percent growth inhibition at one concentration: 29.1%
For compound 3 the middle estimate is 35.9 percentage points above the measured one; measured number below the stated range.
By their numbers in this assay, from the lowest: compound 3; then compound 2; then compound 1.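

Bromo is not a neutral replacement at this aromatic carbon, meta to a large group: in this assay the change from methoxy gives a number 27.2 percentage points lower from compound 2 to compound 3 (beyond the scatter), and this goes in the same direction as the earlier change from hydroxy to methoxy, a number 24.4 percentage points lower from compound 1 to compound 2 (beyond the scatter). Replacing hydroxy directly with bromo gives a number 51.6 percentage points lower from compound 1 to compound 3 (beyond the scatter), so the three compounds now form a clear order at this one position, with the hydroxy compound 1 highest, the methoxy compound 2 in the middle and the bromo compound 3 lowest, each step beyond the scatter. Nothing available bears on what lies behind this order.

Three substituents at a single position cannot show which feature of the group tracks growth inhibition, and the order holds only for these compounds at the one concentration tested. As far as these compounds go, it remains open whether an amine, a carboxylic acid or a hydroxymethyl group on this carbon would stay close to compound 1 or fall towards compound 3, and whether a hydroxy group elsewhere on the same ring would keep the higher number.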